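This account rests on a few compounds, and the source may have more. Where it says the series, first, only, none or still open, it means among the compounds named here.

Among the compounds with values here, both compounds measured so far share one core and differ only in the group on a saturated chain carbon bound to an aromatic nitrogen. Compound 1 `Ic1ccc(Cn2cc(CCCOc3cccc4cccnc34)nn2)cc1` carries a 4-iodophenyl there, and in a functional assay on PC-3 cells (Homo sapiens) for inhibition, read by sulforhodamine B assay, with a stated time of 48 h (a lower number here means a stronger inhibitor of growth, a higher number a weaker inhibitor of growth), compound 1 gives 24.7 ug/mL. Compound 2 `Brc1ccc(Cn2cc(CCCOc3cccc4cccnc34)nn2)cc1` carries a 4-bromophenyl in its place, and in this assay compound 2 gives 8.4 ug/mL. Within the data shown here, the single step known, a 2.9-fold lower number from compound 1 to compound 2 (0.47 log units; beyond the scatter), is modest but lies beyond the scatter, so compound 2 stands at the lower of the two numbers and compound 1 above it.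

Compound 3 `Fc1ccc(Cn2cc(CCCOc3cccc4cccnc34)nn2)cc1F` is the next variation at the same position: 3,4-difluorophenyl in place of 4-bromophenyl on a saturated chain carbon bound to an aromatic nitrogen. Among the measured compounds shown here, only the step from compound 1 to compound 2 bears on this change, since it is the only one that swaps the halogen pattern on that phenyl, and it was modest. The new group is again a halogenated phenyl, now with two fluorines, and nothing measured tells how a second halogen or a fluorine in place of a bromine acts here. Compound 3 is therefore expected to land near compound 2, with the step of a 1.2-fold higher number from compound 2 to compound 3 (0.08 log units; within the scatter) estimated to stay within or close to the scatter. The estimate for compound 3 in this assay is 10 ug/mL, with a range from 3.5 ug/mL to 35 ug/mL.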

Compound 3, concentration for 50% growth inhibition: 6.6 ug/mL
Compound 3: middle estimate off by 1.5-fold (0.18 log units), on the high side; measured number inside the range.
By their numbers in this assay, from the lowest: compounds 3 and 2 (each within the scatter of the next); then compound 1.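

Replacing the 4-bromophenyl with a 3,4-difluorophenyl on a saturated chain carbon bound to an aromatic nitrogen gives a 1.3-fold lower number from compound 2 to compound 3 (0.10 log units; within the scatter), so in this assay this change of halogen type and number leaves compound 2 and compound 3 indistinguishable. Against the 4-iodophenyl, the same 3,4-difluorophenyl gives a 3.7-fold lower number from compound 1 to compound 3 (0.57 log units; beyond the scatter), so among the three groups shown, compound 1 alone stands apart, while two quite different halogen patterns give matching results. No accompanying measurement explains why the 4-iodophenyl differs from the other two groups or why the 4-bromophenyl and 3,4-difluorophenyl match.

The compounds shown leave open whether a plain phenyl, a 4-chlorophenyl, a 4-fluorophenyl or a 3-fluorophenyl would fall with compound 2 and compound 3 or with compound 1, and so whether either fluorine alone can stand in for the pair. Also open, as far as these compounds go, is how this position would respond to a phenyl bearing an amine or a carboxylic acid, or to a longer chain carrying the phenyl ring.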